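The source may report more compounds than this note shows. Statements on the series, on what has been measured and on what is new or still open speak of the compounds shown alone.

Working notes on the series. Going by the values given here, the shared core carries an aryl group on a double-bonded nitrogen, and the three measured members differ only in that aryl group. Compound 1 `Cc1nc2c([nH]1)C(=O)/C(=N/c1ccc(C(F)(F)F)cc1)C(Cl)=C2O` gives 1100 nM in a functional assay on NIH3T3 cells (Mus musculus) for antiproliferative activity; a higher number here means a weaker inhibitor, a lower number a stronger inhibitor. Compound 2 `Cc1nc2c([nH]1)C(=O)/C(=N/c1cccc(Cl)c1)C(Cl)=C2O` gives 1600 nM in this assay, numerically the highest of the three numbers shown, though its gaps to both other compounds are within the scatter. Compound 3 `Cc1nc2c([nH]1)C(=O)/C(=N/c1ccc(Cl)cc1)C(Cl)=C2O` gives 1300 nM in this assay. The step of a 1.2-fold higher number from compound 1 to compound 3 (0.07 log units; within the scatter) shows that exchanging the group on the aromatic carbon leaves the number essentially unchanged, and the step of a 1.2-fold lower number from compound 2 to compound 3 (0.09 log units; within the scatter) shows the same for changing 3-chlorophenyl to 4-chlorophenyl.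

Compound 4 `Cc1nc2c([nH]1)C(=O)/C(=N/c1ccc(F)cc1)C(Cl)=C2O` has not yet been measured. It differs from compound 2 by 4-fluorophenyl in place of 3-chlorophenyl on a double-bonded nitrogen. Both measured steps bear on this change: one exchanges the substituent on the aromatic carbon, the other changes 3-chlorophenyl to 4-chlorophenyl, and both lie within the scatter. No step beyond the scatter is therefore expected in this assay on going to compound 4. Compound 4 is expected to give 1400 nM, with a range of 700 nM to 2800 nM. The expected step is a 1.1-fold lower number from compound 2 to compound 4 (0.06 log units; within the scatter).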

Compound 4, half-maximal inhibitory concentration: 1200 nM
Compound 4: the middle estimate sits 1.2-fold (0.07 log units) above what was measured, and the stated range covers the measured number.
By their numbers in this assay, from the lowest: compounds 1, 4, 3 and 2 (each within the scatter of the next).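

In this assay, the step of a 1.1-fold lower number from compound 3 to compound 4 (0.03 log units; within the scatter) and the step of a 1.1-fold higher number from compound 1 to compound 4 (0.04 log units; within the scatter) add fluoro to the exchanges on the aromatic carbon, so fluoro, chloro and trifluoromethyl now give numbers within the scatter of one another in otherwise identical compounds. The step of a 1.3-fold lower number from compound 2 to compound 4 (0.12 log units; within the scatter) changes both the halogen and the aryl group's name at once, with 4-fluorophenyl in place of 3-chlorophenyl on a double-bonded nitrogen, and it too stays within the scatter, so this read-out separates none of the four aryl groups shown. No supporting data are available to explain why these numbers lie so close together.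

The substituents shown are limited to halogens and trifluoromethyl, so it remains open whether an amine, a carboxylic acid or a longer alkyl chain on the aryl group would move the number beyond the scatter. Going by these compounds alone, compound 2 is also the only example carrying a 3-chlorophenyl group, which leaves that arrangement resting on a single compound.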